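Swapping Isopropyl for Pyridin-2-yl on a Shared Core

The compounds below may be only part of what the source reports. "The series", "measured", "known", "first", "only" and "open" are said of these compounds alone.

Measured so far:
compound 1 `CCOC(=O)Cn1sc2nc(C)cc(C)c2c1=O`: 31%
compound 2 `CC(C)CNC(=O)Cn1sc2ccccc2c1=O`: 54.6%
compound 3 `CCNC(=O)OCCn1sc2nc(C)cc(C)c2c1=O`: 51%

These three compounds were tested in an assay on isolated protein for inhibition of histone acetyltransferase p300 (Homo sapiens), read by fluorescence, with a stated time of 10 min, tested at 50 uM; a higher number here means more inhibition at the concentration tested (going by the name of the read-out), a lower number less inhibition. Compound 2 gives the highest of the three numbers; its gap to compound 3 lies within the usual scatter, so the two cannot be told apart, while compound 1 sits clearly lower, beyond the scatter. Compound 4 `O=C(Cn1sc2ccccc2c1=O)NCc1ccccn1` is not yet measured. It differs from compound 2 in one place: pyridin-2-yl in place of isopropyl on a saturated chain carbon bound to an amide-type nitrogen. Going by the values given here, no measured pair shows this kind of change, so there is no direct guide. The step from compound 2 to compound 4 in this assay is expected to be small, a number 4.6 percentage points lower from compound 2 to compound 4 (within the scatter), likely within the scatter. Compound 4 is therefore estimated at 50%, with a range from 30% to 70%.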

Compound 4, a percentage reported as inhibition, at one concentration (the size of the read-out at that concentration, not a potency): 24%
The estimate for compound 4 lay 26 percentage points above the measured number; the measured number lies below the stated range.
By their numbers in this assay, from the lowest: compounds 4 and 1 (each within the scatter of the next); then compounds 3 and 2 (each within the scatter of the next).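

This position on the amide side chain is sensitive to what it carries: in this assay, exchanging isobutyl for (pyridin-2-yl)methyl gives a number 30.6 percentage points lower from compound 2 to compound 4 (beyond the scatter). Going by these compounds alone, this is the first step in the set that changes only one place, and it shows that this swap costs inhibition at the concentration tested. Nothing measured here explains the loss. From the compounds shown here alone, whether the ring as a whole or its nitrogen matters remains open: a phenyl group in place of pyridin-2-yl would separate the two, while a cyclohexyl group or a longer chain would probe the position further.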